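Estimating acid dissociation for a methoxyphenoxy analogue

A few compounds are considered here, and "the series" means these few. Any claim that something is new, unique, unknown or untested is made for them only; others in the source may bear on it.

Measured compounds:
Compound 1, `CC(C)(C)c1ccc(Oc2ccc3c(NCCCNCc4ccco4)ccnc3c2)cc1`: 9.28
Compound 2, `Fc1ccc(Cc2ccc3c(NCCCNCc4ccco4)ccnc3c2)cc1`: 9.47
Compound 3, `CC(C)(C)c1ccc(-c2ccc3c(NCCCNCc4ccco4)ccnc3c2)cc1`: 9.47

Of the compounds shown here, three sharing one core have been measured in a physicochemical assay for acid dissociation. Compound 3 gives 9.47, level with compound 2 at the digits shown, and together these two are the highest of the three numbers. Compound 1 lies nearest in structure to the new compound and gives 9.28, a number below compound 3 but within the scatter of the method. Within the data shown here, the one measured step that changes a single place, no change at the digits printed from compound 2 to compound 3 (within the scatter), shows no change beyond the scatter when 4-(tert-butyl)phenyl replaces 4-fluorobenzyl.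

Compound 4, `COc1ccc(Oc2ccc3c(NCCCNCc4ccco4)ccnc3c2)cc1`, has not yet been measured. It differs from compound 3 in one place: 4-methoxyphenoxy in place of 4-(tert-butyl)phenyl on an aromatic carbon. Among the measured compounds shown here, no measured step covers this exact exchange. What bears on it is the measured step from compound 2 to compound 3 and the pair of values for compound 1 and compound 3, all of which show differences within the scatter for changes at this position. Compound 4 is therefore expected to move little, with an estimated step of a number 0.15 log units lower from compound 3 to compound 4 (within the scatter). The estimate for compound 4 in this assay is 9.32, within a range from 9 to 9.65.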

Compound 4, acid dissociation constant: 9.28
Compound 4: the middle estimate sits 0.04 log units above what was measured; low and high end bracket the measured number.
By their numbers in this assay, from the lowest: compounds 1, 4, 2 and 3 (each within the scatter of the next).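

In this assay, 4-methoxyphenoxy in place of 4-(tert-butyl)phenyl gives a number 0.19 log units lower from compound 3 to compound 4 (within the scatter) and 4-methoxyphenoxy in place of 4-fluorobenzyl gives a number 0.19 log units lower from compound 2 to compound 4 (within the scatter) so this position on the shared core now carries four different groups, with every step printed for them inside the scatter. Methoxy in place of tert-butyl on an aromatic carbon, a change further out on the same substituent, gives no change at the digits printed from compound 1 to compound 4 (within the scatter) and so adds a comparison that the earlier compounds did not offer, while the exchange of 4-(tert-butyl)phenyl, with 0 hydrogen-bond acceptors, for 4-methoxyphenoxy, with 2, also stays within the scatter. Nothing measured here accounts for how little these numbers separate.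

The compounds shown leave open whether a group of another kind at this position, such as a carboxylic acid or a primary amine, would also stay within the scatter. As far as these compounds go, all four compounds differ only at this one place, so how the number responds to a longer chain or to any other change elsewhere on the shared core remains open.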